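Chloro in Place of Methyl on the Outer Ring

The compounds below may be only part of what the source reports. "The series", "measured", "known", "first", "only" and "open" are said of these compounds alone.

Measured in an assay on isolated protein for inhibition of microsomal triglyceride transfer protein large subunit (Homo sapiens); on this read-out lower numbers stand for stronger inhibition and higher numbers for weaker inhibition:
compound 1 `COC(=O)N[C@@H]1Cc2ccc(NC(=O)c3ccccc3-c3ccc(C(F)(F)F)cc3)cc2C1` gives 110 nM
compound 2 `Cc1ccc(-c2c(C)cccc2C(=O)Nc2ccc3c(c2)CC(NS(=O)(=O)c2ccccc2)C3)cc1` gives 93 nM

Compound 2 has the lower of the two numbers, but compound 1 sits within the scatter of it, so the two cannot be set in order. Compound 3 `Cc1cccc(C(=O)Nc2ccc3c(c2)CC(NS(=O)(=O)c2ccccc2)C3)c1-c1ccc(Cl)cc1` is not yet measured. It differs from compound 2 in one place: chloro in place of methyl on an aromatic carbon. For the measured compounds named here, no step between measured compounds covers this change, so its effect is unknown from these data. Going by the values given here, both groups are single heavy atoms without donors, acceptors or charge, and the only measured compounds sit close together, so a step in this assay beyond the scatter is not expected in either direction. Compound 3 is therefore estimated at 90 nM, with a range from 30 nM to 270 nM. The step of a 1.0-fold lower number from compound 2 to compound 3 (0.01 log units; within the scatter) expected here is small.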

Compound 3, half-maximal inhibitory concentration: 100 nM
Beside the measured number, compound 3's estimate is 1.1-fold (0.05 log units) below it; the range from low to high includes it.
By their numbers in this assay, from the lowest: compounds 2, 3 and 1 (each within the scatter of the next).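

In this assay the change from 4-methylphenyl to 4-chlorophenyl gives a 1.1-fold higher number from compound 2 to compound 3 (0.03 log units; within the scatter) and so stays within the scatter: at this position on the outer ring, para to a large group, the read-out does not separate chloro from methyl. For the compounds shown here, this is the first comparison here that isolates a single place, something compound 1 and compound 2 could not offer, as they differ in several places at once. No measurement of any property of these groups is available to bear on this result.

From the compounds shown here alone, whether the read-out would stay as steady with an amine, a carboxylic acid or a longer chain at this position remains open. Also open, going by these compounds, is whether chloro in place of methyl would read the same way at the other methyl group of compound 3.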